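A few compounds are considered here, and "the series" means these few. Any claim that something is new, unique, unknown or untested is made for them only; others in the source may bear on it.

In a functional assay on the whole organism (strain Wistar) for inhibition, with Rattus norvegicus as the target, read by paw edema, with stated times of 30 min and 3 h, at a dose of 200 mg/kg by the oral route (on this read-out lower numbers stand for less inhibition and higher numbers for more inhibition at the one dose given (going by the name of the read-out)), compound 2 `COc1ccc(-c2cc3c(n2-c2ccc(O)c(C(=O)O)c2)CCCC3)cc1` gives 50%, the highest of the two numbers in hand. Within the data shown here, compound 1 `O=C(O)c1cc(-n2c(-c3ccccc3)cc3c2CCCC3)c(C(F)(F)F)cc1O` gives 0% in this assay, a gap beyond the scatter; the two structures differ in more than one place, so no single step is drawn between them.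

Compound 3 `O=C(O)c1cc(-n2c(-c3ccc([N+](=O)[O-])cc3)cc3c2CCCC3)ccc1O` differs from compound 2 in one place: nitro in place of methoxy on an aromatic carbon. Among the measured compounds shown here, no measured pair covers this change, so its direction is unsupported by data. The expected step is a number 15 percentage points lower from compound 2 to compound 3 (beyond the scatter), downward and near the edge of the scatter. Compound 3 is estimated at 35%, within 10% to 60%.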

Compound 3, a percentage reported as inhibition, in the whole organism at one dose (the size of the read-out at that dose, not a potency): 30%
Beside the measured number, compound 3's estimate is 5 percentage points above it; low and high end bracket the measured number.
By their numbers in this assay, from the lowest: compound 1; then compound 3; then compound 2.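

Among these compounds, the change from 4-methoxyphenyl to 4-nitrophenyl gives the first one-place comparison: in this assay the step is a number 20 percentage points lower from compound 2 to compound 3 (beyond the scatter) and lies beyond the scatter. The number at this position, para to a large group, therefore depends on the group carried there, yet compound 3 still gives 30% and so retains some inhibition. Nothing available here accounts for the step.

Among the compounds shown here, with only two groups compared at this position, no trend can be drawn. An amine or a chlorine atom there would show whether methoxy and nitro mark the ends of a range or merely two points within it.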